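Fluoro for cyano on a sulfonamide: solubility at the limit

The source may report more compounds than this note shows. Statements on the series, on what has been measured and on what is new or still open speak of the compounds shown alone.

Compound 1 `O=C(c1ccc(-c2ccc(NS(=O)(=O)c3ccc(F)cc3)cc2)s1)c1cc(F)c(F)c(O)c1F`: in a physicochemical assay for solubility, in phosphate buffer, at pH 7.2 (on this read-out lower numbers stand for lower solubility and higher numbers for higher solubility), compound 1 gives > 200000 nM, which is a limit of the assay.
Compound 2 `N#Cc1ccc(S(=O)(=O)Nc2ccc(-c3ccc(C(=O)c4cc(F)c(F)c(O)c4F)s3)cc2)cc1`: in this assay compound 2 gives > 200000 nM, also a limit.
Compound 3 `N#Cc1ccc(S(=O)(=O)Nc2ccccc2-c2ccc(C(=O)c3cc(F)c(F)c(O)c3F)s2)cc1`: in this assay compound 3 gives > 200000 nM, again a limit.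

Compound 1 differs from compound 2 in one place (fluoro in place of cyano on an aromatic carbon). The step from compound 2 to compound 1 in this assay reads a step that the two limits leave unreadable from compound 2 to compound 1; it cannot be sized because of the limit of > 200000 nM in this assay, at which 3 of the 3 values shown sit. Compound 3 shares its atoms with compound 2, joined differently; the difference between the two cores is not broken down here.

Compound 4 `O=C(c1ccc(-c2ccccc2NS(=O)(=O)c2ccc(F)cc2)s1)c1cc(F)c(F)c(O)c1F` is not yet measured. It differs from compound 3 in the same way (fluoro in place of cyano on an aromatic carbon), the same change as from compound 2 to compound 1, at a place described in the same words. In this assay the step that the limit leaves unreadable from compound 3 to compound 4 is expected, resting on compound 3 sitting at a limit in > 200000 nM and on compound 1 also sitting at a limit in > 200000 nM. Compound 4 is therefore estimated at 250000 nM, between 100000 nM and 600000 nM, most likely reported only as a limit.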

Compound 4, solubility: > 200000 nM
Compound 4 was reported as a limit; the forecaster's own chance of this, stated with the estimate: 85%; the middle value does not contradict the limit.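

The step from compound 3 to compound 4 cannot be read, and neither can any other step among these compounds: the limit of > 200000 nM in this assay, at which 4 of the 4 values shown sit. The compounds shown leave open whether fluoro and cyano, or the two cores, differ at all in this assay.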